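Amino to Chlorophenyl Imine on the Shared Core

The source may hold more compounds than are shown below. What is called first, only, known or untested is meant among the compounds shown, and "the series" means these compounds.

The three measured compounds share one core and were all read in a functional assay on SF-268 cells (Homo sapiens) for inhibition, read by sulforhodamine B assay, with a stated time of 72 h; a lower number here means a stronger inhibitor, a higher number a weaker inhibitor. Compound 1 `Cc1nc2cc(Br)ccc2n(CC(=O)NN)c1=O` gives 0.00006 ug/mL, compound 2 `Cc1nc2cc(Br)ccc2nc1Oc1ccccc1N` gives 0.00006 ug/mL, and compound 3 `Cc1nc2cc(Br)ccc2nc1Oc1ccc(N)cc1` gives 0.00008 ug/mL. Compound 3 has the highest of the three numbers, yet its gaps to compound 1 and to compound 2 both fall within the usual scatter, so the three stand together and no order among them can be claimed.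

Compound 4 `Cc1nc2cc(Br)ccc2nc1Oc1ccc(/N=C\c2ccc(Cl)cc2)cc1` has not been measured. Relative to compound 3 it carries a group of 9 heavy atoms (7 carbon, 1 nitrogen, 1 chlorine; one six-membered aromatic ring of carbon only) in place of one nitrogen atom, on an aromatic carbon, in words a group of 9 heavy atoms (7 carbon, 1 nitrogen, 1 chlorine; one six-membered aromatic ring of carbon only) in place of one nitrogen atom, on an aromatic carbon. For the measured compounds named here, no pair of measured compounds differs in one place, so no step is available to calibrate this change. Since the three known values sit within the scatter of one another despite different substituents, compound 4 is expected to stay near them, with the step of a 1.3-fold higher number from compound 3 to compound 4 (0.10 log units; within the scatter) estimated as no more than a small weakening. Compound 4 is estimated at 0.0001 ug/mL in this assay, within a range from 0.00003 ug/mL to 0.0004 ug/mL.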

Compound 4, half-maximal inhibitory concentration: 0.00002 ug/mL
Estimate against measurement, compound 4: 5.0-fold (0.70 log units) above; measured number below the stated range.
By their numbers in this assay, from the lowest: compound 4; then compounds 1, 2 and 3 (each within the scatter of the next).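

For the compounds shown here, the amino position, on an aromatic carbon para to a large group, accepts a far larger substituent without loss in this assay: the change gives a 4.0-fold lower number from compound 3 to compound 4 (0.60 log units; beyond the scatter), the one step here that lies beyond the scatter. The entering group has no hydrogen-bond donor, so a donor at this place is not needed for a number as low as that of compound 4. Nothing at hand explains why the number falls.

The chlorine, the carbon ring and the double bond all enter together, so the compounds shown do not tell which of them carries the step. Nothing here shows how the same imine would read with a methoxy group or a fluorine in place of the chlorine, or with no halogen on that ring.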